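Cytotoxicity notes: amide-nitrogen ring variation, compound 4

This account rests on a few compounds, and the source may have more. Where it says the series, first, only, none or still open, it means among the compounds named here.

Measured so far in an ADME assay on MT4 cells (Homo sapiens) for cytotoxicity, read by MTT assay, with a stated time of 5 days; on this read-out higher numbers stand for lower toxicity in this test and lower numbers for higher toxicity in this test:
compound 1 `Cc1cc(C)cc(S(=O)(=O)c2c(C(=O)NC3CNC3)[nH]c3ccc(Cl)cc23)c1` gives 37300 nM
compound 2 `Cc1cc(C)cc(S(=O)(=O)c2c(C(=O)N[C@@H]3CCNC3)[nH]c3ccc(Cl)cc23)c1` gives 37300 nM
compound 3 `Cc1cc(C)cc(S(=O)(=O)c2c(C(=O)N[C@@H]3CCN(Cc4cccnc4)C3)[nH]c3ccc(Cl)cc23)c1` gives 36500 nM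

Compound 2 stands level with compound 1 at the digits shown, the two together giving the highest numbers of the three, and its step to compound 3 is a 1.0-fold lower number from compound 2 to compound 3 (0.01 log units; within the scatter).

Compound 4 `Cc1cc(C)cc(S(=O)(=O)c2c(C(=O)NC3CN(S(C)(=O)=O)C3)[nH]c3ccc(Cl)cc23)c1` differs from compound 2 by 1-(methylsulfonyl)azetidin-3-yl in place of pyrrolidin-3-yl on an amide-type nitrogen. For the measured compounds named here, two measured steps bear on this: the ring-size change is the reverse of no change at the digits printed from compound 1 to compound 2 (within the scatter), and adding a group on the ring amine nitrogen gave a 1.0-fold lower number from compound 2 to compound 3 (0.01 log units; within the scatter). Both stayed within the scatter, so no step beyond the scatter is expected here, a 1.0-fold lower number from compound 2 to compound 4 (0.00 log units; within the scatter). Compound 4 is therefore expected to give about 37000 nM in this assay, in the range 18000 nM to 75000 nM.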

Compound 4, half-maximal cytotoxic concentration: > 252000 nM
Compound 4: no number, only a limit; the forecaster's own chance of this, stated with the estimate: 20%; middle value at least 6.8-fold (0.83 log units) from the limit.
By their numbers in this assay, from the lowest: compounds 3, 1 and 2 (each within the scatter of the next). At a limit, above all of these: compound 4.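

In this assay compound 4 stands only at a limit, not at a number: the limit of > 252000 nM in this assay, at which 1 of the 4 values shown sits.
Methylsulfonyl on the ring amine nitrogen is the first change here to move the read-out beyond the scatter, towards lower toxicity in this test, with an at least 6.7-fold higher number from compound 1 to compound 4 (0.82 log units; beyond the scatter). Substitution on this nitrogen therefore depends on the group: a 1.0-fold lower number from compound 2 to compound 3 (0.01 log units; within the scatter), yet an at least 6.9-fold higher number from compound 3 to compound 4 (0.83 log units; beyond the scatter) and an at least 6.7-fold higher number from compound 2 to compound 4 (0.82 log units; beyond the scatter).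

Open, going by these compounds, is whether methylsulfonyl on the pyrrolidin-3-yl ring would give the same shift. Also open, on these data alone, is whether an acetyl or a plain methyl on the ring amine nitrogen would do so.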